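The source may hold more compounds than are shown below. What is called first, only, known or untested is meant among the compounds shown, and "the series" means these compounds.

Among the measured compounds shown here, compound 2 `Cc1ccccc1-c1ccccc1OC(C)C1=NCCN1` gives 363 nM in a functional assay on CHO cells for agonist activity at Alpha-2C adrenergic receptor (Homo sapiens) (a lower number here means that less compound is needed, a higher number that more compound is needed for the effect), the lower of the two numbers measured so far. Compound 1 `Cc1ccc(-c2ccccc2OC(C)C2=NCCN2)cc1` gives 832 nM in this assay. For the measured compounds named here, the only measured step, a 2.3-fold lower number from compound 1 to compound 2 (0.36 log units; beyond the scatter), shows that moving the methyl group on the attached ring from one spot to another shifts the number by a modest amount. Compound 3 `Cc1cccc(-c2ccccc2OC(C)C2=NCCN2)c1` differs from compound 2 by 3-methylphenyl in place of 2-methylphenyl on an aromatic carbon. Going by the values given here, no measured step tells how this third arrangement of the methyl group behaves in this assay, so the step of a 2.3-fold lower number from compound 1 to compound 2 (0.36 log units; beyond the scatter) is the only guide, and it suggests that the new arrangement should land near the two measured numbers rather than far from them. The expected step is a 1.5-fold higher number from compound 2 to compound 3 (0.18 log units; within the scatter), which may well stay within the scatter. Compound 3 is therefore estimated at 550 nM in this assay, with a range from 250 nM to 1200 nM.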

Compound 3, half-maximal effective concentration: 1580 nM
The estimate for compound 3 lay 2.9-fold (0.46 log units) below the measured number; the measured number lies above the stated range.
By their numbers in this assay, from the lowest: compound 2; then compounds 1 and 3 (each within the scatter of the next).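

In this assay, all three placements of the methyl group on the attached ring can now be compared, and only the 2-methylphenyl group of compound 2 stands apart, with a 4.4-fold higher number from compound 2 to compound 3 (0.64 log units; beyond the scatter). The 3-methylphenyl and 4-methylphenyl groups cannot be separated, with a 1.9-fold higher number from compound 1 to compound 3 (0.28 log units; within the scatter), so these three compounds show no steady trend as the methyl group changes place; the lower number belongs to the 2-methylphenyl arrangement alone. Nothing available here explains why this one arrangement differs.

Every compound shown carries a methyl group on this ring, so it remains open whether an ethyl group, a chlorine atom or a methoxy group would show the same dependence on placement. On these data alone, the shared core is also the same throughout, so it is unknown whether this preference would survive a change elsewhere in the molecule.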